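The source may hold more compounds than are shown below. What is called first, only, known or untested is meant among the compounds shown, and "the series" means these compounds.

Working notes on the series.

Measured compounds:
Compound 1, `N=c1c(=O)[nH]nc2n1CCN2c1cccc(Cl)c1`: in a functional assay on T47D cells (Homo sapiens) for cytotoxicity, with a stated time of 72 h, tested at 50 ug/mL (on this read-out lower numbers stand for a weaker effect and higher numbers for a stronger effect at the one concentration tested), compound 1 gives 31%.
Compound 2, `N/N=C1\NCCN1c1ccccc1`: in this assay compound 2 gives 0%.
Compound 3, `N=c1c(=O)[nH]nc2n1CCN2c1ccccc1`: in this assay compound 3 gives 3%.

Compound 3 and compound 1 share a core and differ in one place, (chloro in place of hydrogen on an aromatic carbon). This single change gives a number 28 percentage points higher from compound 3 to compound 1 (beyond the scatter), a modest step that lies beyond the scatter. Compound 2 carries a different core from compound 3; the difference between the two cores is not broken down here. Compound 2 and compound 3 give numbers within the scatter of each other, so nothing can be said about their order.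

Compound 4, `N/N=C1\NCCN1c1cccc(Cl)c1`, has not yet been measured in this assay. It relates to compound 2 as compound 1 relates to compound 3, (chloro in place of hydrogen on an aromatic carbon). The two sites are not described word for word alike: in compound 2 the site is meta to a group of 7 heavy atoms, whereas in compound 3 it is meta to a large group. Among the measured compounds shown here, the change from compound 2 to compound 4 is therefore the same kind of change as the one from compound 3 to compound 1, not the same change, and the only measured occurrence of it stands on the other core.

For compound 4 a step of a number 12 percentage points higher from compound 2 to compound 4 (beyond the scatter) is expected, smaller than the measured one, because the measured step of a number 28 percentage points higher from compound 3 to compound 1 (beyond the scatter) belongs to the other core and compound 2 starts from 0%. Compound 4 is estimated at 12%, with a range from 0% to 30%.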

Compound 4, a percentage reported as inhibition, at one concentration (the size of the read-out at that concentration, not a potency): 0%
The estimate for compound 4 lay 12 percentage points above the measured number; low and high end bracket the measured number.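

In this assay, chloro in place of hydrogen on an aromatic carbon gives no change at the digits printed from compound 2 to compound 4 (within the scatter), so the step seen on the core of compound 3 does not carry over unchanged to the core of compound 2: the same change on two cores in this assay, a number 28 percentage points higher (beyond the scatter) from compound 3 to compound 1 and no change at the digits printed (within the scatter) from compound 2 to compound 4, 28 percentage points apart, beyond the scatter of two such steps

This is a caution against moving the size of the step from one core to the other in this series, but it rests on a single pair on each core, with the change at a single site and the read-out taken at a single concentration. Compound 2 gives 0% and compound 4 gives 0%, and these two numbers do not show whether the pair would separate at another concentration, nor do they explain why the two cores part.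

Open, on these data alone, is whether an amine or a carboxylic acid in place of the chloro would also give steps that differ between the two cores. Also open, as far as these compounds go, is whether a longer chain on the aromatic ring would follow the chloro pattern on either core.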